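A few compounds are considered here, and "the series" means these few. Any claim that something is new, unique, unknown or untested is made for them only; others in the source may bear on it.

Two compounds carrying the same thioether-linked oxime core have been taken through a functional assay on the whole organism (strain albino) for inhibition, with Rattus norvegicus as the target, read by paw edema, with a stated time of 5 h, at a dose of 0.28 mmol/kg by the oral route; a higher number here means more inhibition at the dose given (going by the name of the read-out), a lower number less inhibition. Compound 1 `O/N=C(/CSc1nnc(-c2ccccc2)n1-c1ccccc1)c1ccccc1` gives 75% in this assay. Compound 2 `CCn1c(SC/C(=N/O)c2ccccc2)nnc1-c1ccc(OC)cc1` gives 71% in this assay, which is the lower of the two numbers recorded; the value of compound 1 sits so close to it that the gap falls within the usual scatter, so the two read as equivalent rather than ordered.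

Compound 3 `CCn1c(SC/C(=N/O)c2ccccc2)nnc1-c1ccccc1` is the next member of the series and has not yet been measured in this assay. Within the data shown here, its single departure from compound 2 is hydrogen in place of methoxy on an aromatic carbon. Among the measured compounds shown here, no step between two measured compounds in this assay has been recorded, so there is no precedent in the set for what such a change does to the read-out. Given that compound 1 and compound 2, which differ at more than one position, still land within the scatter of one another, the expectation is that compound 3 shows no shift beyond the scatter, with a number 1 percentage points higher from compound 2 to compound 3 (within the scatter) as the estimated step. Compound 3 is therefore expected to give about 72% in this assay, with a range from 60% to 82%.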

Compound 3, a percentage reported as inhibition, in the whole organism at one dose (the size of the read-out at that dose, not a potency): 71%
For compound 3 the middle estimate is 1 percentage points above the measured one; the measured number falls inside the stated range.
By their numbers in this assay, from the lowest: compounds 2, 3 and 1 (each within the scatter of the next).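

Both steps in this assay can now be read as changes in one place. On the six-membered aromatic ring, going from 4-methoxyphenyl to phenyl gives no change at the digits printed from compound 2 to compound 3 (within the scatter), so among these compounds the methoxy group is not needed to hold the inhibition of paw edema at this dose. On the aromatic nitrogen, ethyl in place of phenyl gives a number 4 percentage points lower from compound 1 to compound 3 (within the scatter), which separates this change from the methoxy change that compound 1 and compound 2 carried together, and neither step lies beyond the scatter. Nothing available explains why either change leaves the read-out within the scatter.

From the compounds shown here alone, it remains open whether a different group at the ring carbon, such as an amine or a carboxylic acid, or a longer chain such as butyl on the aromatic nitrogen, would move the number beyond the scatter. Going by these compounds, since each compound is read at a single dose, how compound 1, compound 2 and compound 3 would compare at other doses also remains open.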